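The source may report more compounds than this note shows. Statements on the series, on what has been measured and on what is new or still open speak of the compounds shown alone.

Working notes on the series. Compound 1 `Brc1cn2ccnc2c(-c2ccc3ncn(C4CCCCC4)c3c2)n1` carries bromo on an aromatic carbon of the shared core; in a functional assay on ACHN cells (Homo sapiens) for inhibition, read by sulforhodamine B assay, with a stated time of 48 h, tested at 10 uM (a higher number here means more inhibition at the concentration tested (going by the name of the read-out), a lower number less inhibition), compound 1 gives 11.5%. Compound 2 `c1ccc2c(-c3cn4ccnc4c(-c4ccc5ncn(C6CCCCC6)c5c4)n3)cccc2c1` carries naphthalen-1-yl in place of bromo, and in this assay compound 2 gives 6.49%. Compound 3 `Clc1ccc(-c2cn3ccnc3c(-c3ccc4ncn(C5CCCCC5)c4c3)n2)cc1` carries 4-chlorophenyl in place of bromo, and in this assay compound 3 gives 5.45%. None of the three is separated from another beyond the scatter: a number 5 percentage points lower from compound 1 to compound 2 (within the scatter), a number 6.1 percentage points lower from compound 1 to compound 3 (within the scatter) and a number 1 percentage points lower from compound 2 to compound 3 (within the scatter). Compound 3 has the lowest of the three numbers, yet both compound 2 and compound 1 sit within the scatter of it, so no order among the three can be read.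

Compound 4 `COc1ccccc1-c1cn2ccnc2c(-c2ccc3ncn(C4CCCCC4)c3c2)n1` is the next member; its difference from compound 3 is 2-methoxyphenyl in place of 4-chlorophenyl on an aromatic carbon. Among the compounds with values here, the steps that bear on this are the two aryl exchanges already seen: swapping one aryl group for another, a number 1 percentage points lower from compound 2 to compound 3 (within the scatter), and replacing bromo by aryl, a number 6.1 percentage points lower from compound 1 to compound 3 (within the scatter), both within the scatter. A third aryl group on the same aromatic carbon is therefore expected to give no step beyond the scatter in this assay; the expected step is a number 2.6 percentage points higher from compound 3 to compound 4 (within the scatter). Compound 4 is estimated at 8%, with a range from 0% to 20%.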

Compound 4, a percentage reported as inhibition, at one concentration (the size of the read-out at that concentration, not a potency): 4.48%
Beside the measured number, compound 4's estimate is 3.5 percentage points above it; the measured number falls inside the stated range.
By their numbers in this assay, from the lowest: compounds 4, 3, 2 and 1 (each within the scatter of the next).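

In this assay, within the data shown here, the first aryl group to carry an oxygen, 2-methoxyphenyl, gives no step beyond the scatter against any earlier group on this aromatic carbon: a number 1 percentage points lower from compound 3 to compound 4 (within the scatter), a number 2 percentage points lower from compound 2 to compound 4 (within the scatter) and a number 7 percentage points lower from compound 1 to compound 4 (within the scatter). The position next to the ring nitrogen has now held bromo, naphthalen-1-yl, 4-chlorophenyl and 2-methoxyphenyl, and with all four compounds within the scatter of one another, neither the exchange of chlorine for a methoxy group nor the change in where the substituent stands on the phenyl ring can be told from no change in this read-out. No accompanying measurement bears on why these groups are not separated, so the result stays a plain observation.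

Still open, on these data alone, is whether a group of a different kind on this carbon, such as a basic amine like piperazine, a carboxylic acid or a longer alkyl chain, would give a step beyond the scatter from compound 1. Also open, as far as these compounds go, is whether replacing the cyclohexyl group elsewhere on the shared core, for instance with a smaller cyclopropyl ring, would move the number in this assay.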